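Carboxymethyl in Place of the Acylurea: Expected Tolerated Concentration

The compounds below may be only part of what the source reports. "The series", "measured", "known", "first", "only" and "open" are said of these compounds alone.

Compound 1 `CCOC(=O)NC(=O)NC1=CS(=O)(=O)O[C@@]12[C@@H](CO[Si](C)(C)C(C)(C)C)O[C@@H](n1cc(C)c(=O)n(C)c1=O)[C@@H]2O[Si](C)(C)C(C)(C)C` gives 16000 nM in a functional assay on HEL cells (Homo sapiens) for cytotoxicity, read by microscopy; a higher number here means that more compound is tolerated, a lower number that less compound is tolerated.
Compound 2 `COC(=O)CCNC1=CS(=O)(=O)O[C@@]12[C@@H](CO[Si](C)(C)C(C)(C)C)O[C@@H](n1cc(C)c(=O)n(C)c1=O)[C@@H]2O[Si](C)(C)C(C)(C)C` gives >= 400000 nM in this assay, which is a limit of the assay and not a number.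
Compound 3 `C=C(C)C(=O)NC(=O)NC1=CS(=O)(=O)O[C@@]12[C@@H](CO[Si](C)(C)C(C)(C)C)O[C@@H](n1cc(C)c(=O)n(C)c1=O)[C@@H]2O[Si](C)(C)C(C)(C)C` gives 20000 nM in this assay.

Compound 3 and compound 1 lie within the scatter of each other, as a 1.3-fold higher number from compound 1 to compound 3 (0.10 log units; within the scatter) shows; the value of compound 2 is a limit. Compound 4 `Cc1cn([C@@H]2O[C@H](CO[Si](C)(C)C(C)(C)C)[C@@]3(OS(=O)(=O)C=C3NCC(=O)O)[C@H]2O[Si](C)(C)C(C)(C)C)c(=O)n(C)c1=O` differs from compound 3 in one place: carboxymethyl in place of ((1-methylethenyl)carbonyl)carbamoyl on an amine nitrogen. Within the data shown here, the steps that bear on this change are the two that exchange the group on the same amine nitrogen, an at least 25-fold higher number from compound 1 to compound 2 (1.39 log units; beyond the scatter) and an at least 20-fold lower number from compound 2 to compound 3 (1.30 log units; beyond the scatter), both large. A large upward step is therefore expected in this assay, so that a 10-fold higher number from compound 3 to compound 4 (1.00 log units; beyond the scatter) is estimated, with a fair chance that only a limit is reported, as the limit of >= 400000 nM in this assay, at which 1 of the 3 values shown sits, shows for compound 2. Compound 4 is thus expected at 200000 nM, range 40000 nM to 400000 nM.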

Compound 4, minimum cytotoxic concentration: 300000 nM
Compound 4: the middle estimate sits 1.5-fold (0.18 log units) below what was measured; the range from low to high includes it.
By their numbers in this assay, from the lowest: compounds 1 and 3 (each within the scatter of the next); then compound 4. At a limit, above all of these: compound 2.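

In this assay, carboxymethyl on the amine nitrogen goes with large rises over both carbamoyl-bearing compounds: a 15-fold higher number from compound 3 to compound 4 (1.18 log units; beyond the scatter) and a 19-fold higher number from compound 1 to compound 4 (1.27 log units; beyond the scatter). The large rise seen earlier with 2-(methoxycarbonyl)ethyl therefore also appears with a second group, this time as a measured number. The remaining step, an at least 1.3-fold lower number from compound 2 to compound 4 (0.12 log units; that floor lies within the scatter), does not order these two compounds, since compound 2 stands at a limit: the limit of >= 400000 nM in this assay, at which 1 of the 4 values shown sits.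

On these data alone, whether a plain amine or a longer chain ending in a carboxylic acid on this nitrogen would give similar numbers stays open.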